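This account rests on a few compounds, and the source may have more. Where it says the series, first, only, none or still open, it means among the compounds named here.

Measured so far in a functional assay on HeLa cells (Homo sapiens) for inhibition, read by MTT assay, with a stated time of 48 h; a higher number here means a weaker inhibitor, a lower number a stronger inhibitor:
- compound 1 `CCOC(=O)C1=C(N/C=N/c2cccnc2Cl)Nc2[nH]nc(C)c2C1c1ccc(N(C)C)cc1` gives 4630 nM
- compound 2 `CCOC(=O)C1=C(N/N=C(\C#N)C(N)=O)Nc2[nH]nc(C)c2C1c1ccc(N(C)C)cc1` gives 47300 nM
- compound 3 `CCOC(=O)C1=C(N/N=C(/Cl)c2ccc([N+](=O)[O-])cc2)Nc2[nH]nc(C)c2C1c1ccc(N(C)C)cc1` gives 46200 nM

Compound 3 belongs to the upper pair of numbers. The step of a 1.0-fold lower number from compound 2 to compound 3 (0.01 log units; within the scatter) leaves it level with its partner, whereas a 10-fold higher number from compound 1 to compound 3 (1.00 log units; beyond the scatter) marks its distance from the low number, and a 10-fold higher number from compound 1 to compound 2 (1.01 log units; beyond the scatter) gives the same picture for the partner.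

The next structure is compound 4 `CCOC(=O)C1=C(N/N=C(/Br)c2ccccc2)Nc2[nH]nc(C)c2C1c1ccc(N(C)C)cc1`, and the change is a group of 9 heavy atoms (7 carbon, 1 nitrogen, 1 bromine; one six-membered aromatic ring of carbon only) in place of a group of 12 heavy atoms (7 carbon, 2 nitrogen, 2 oxygen, 1 chlorine; one six-membered aromatic ring of carbon only), on an amine nitrogen here. One six-membered aromatic ring of carbon only remains in the group on that amine nitrogen.

Going by the values given here, no measured step isolates this change. The closest guide is a 1.0-fold lower number from compound 2 to compound 3 (0.01 log units; within the scatter) as a case of two unlike groups on the same amine nitrogen giving numbers within the scatter of each other. Compound 1 goes against any reading of that nitrogen as insensitive, since compound 1 gives 4630 nM and the estimate is therefore held loosely. The anchor remains compound 3 at 46200 nM as the nearest structure.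

In this assay the estimated step is a 1.3-fold lower number from compound 3 to compound 4 (0.12 log units; within the scatter) and no clear direction is expected beyond the scatter. For compound 4 the expected value is 35000 nM with an estimated range from 10000 nM to 90000 nM in these working notes.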

Compound 4, half-maximal inhibitory concentration: 75700 nM
Compound 4: the middle estimate sits 2.2-fold (0.34 log units) below what was measured; the measured number falls inside the stated range.
By their numbers in this assay, from the lowest: compound 1; then compounds 3, 2 and 4 (each within the scatter of the next).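

In this assay, a 1.6-fold higher number from compound 3 to compound 4 (0.21 log units; within the scatter) and a 1.6-fold higher number from compound 2 to compound 4 (0.20 log units; within the scatter) put compound 4 level with the upper pair, so three unlike groups on the amine nitrogen now give numbers within the scatter of one another. This holds even though the group with 3 hydrogen-bond acceptors and 2 double bonds outside aromatic rings gives way to one with 1 hydrogen-bond acceptor and 1 such double bond. The a 16-fold higher number from compound 1 to compound 4 (1.21 log units; beyond the scatter) separates two groups that both have 9 heavy atoms and one six-membered aromatic ring, so heavy-atom count and the presence of a ring do not by themselves account for compound 1 being the strongest inhibitor of the four; no measurement shown explains that separation.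

Compound 1 remains the only member whose group has a ring with 1 hetero atom, and its group also differs from the others in the chain linking that ring to the amine nitrogen, so the compounds shown do not assign the gap to either feature. Also open, from the compounds shown here alone, is how a carboxylic acid or a primary amine on the aromatic ring of the compound 1 group would read in this assay.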